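Urea-to-amide change in the pyrazole series at one concentration

This account rests on a few compounds, and the source may have more. Where it says the series, first, only, none or still open, it means among the compounds named here.

Compound 3 `COc1cc(Cl)cc(-c2nn(-c3cccc(NC(=O)Nc4cccc(C(F)(F)F)c4)c3)cc2-c2ccncc2)c1` gives 99% in a functional assay on RPMI-8226 cells (Homo sapiens) for inhibition, read by sulforhodamine B assay, with a stated time of 48 h, tested at 0.01 uM; on this read-out higher numbers stand for a weaker effect at the one concentration tested and lower numbers for a stronger effect; compound 2 `COc1cc(Cl)cc(-c2nn(-c3cccc(NC(=O)Nc4ccc(Cl)c(Cl)c4)c3)cc2-c2ccncc2)c1` gives 99% and compound 1 `COc1cc(Cl)cc(-c2nn(-c3cccc(NC(=O)Nc4ccc(Cl)c(C(F)(F)F)c4)c3)cc2-c2ccncc2)c1` gives 97%. Compound 3 stands level with compound 2 at the digits printed, the pair being the highest of the three numbers, and the gap to compound 1, the furthest, is a number 2 percentage points higher from compound 1 to compound 3 (within the scatter). The other measured steps, a number 2 percentage points higher from compound 1 to compound 2 (within the scatter) and no change at the digits printed from compound 2 to compound 3 (within the scatter), likewise stay inside the scatter, so all three numbers sit near the top of the scale, where higher numbers mean a weaker effect at the single concentration.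

Compound 4 `COc1cc(Cl)cc(-c2nn(-c3cccc(NC(=O)c4cccc(C(F)(F)F)c4)c3)cc2-c2ccncc2)c1` differs from compound 3 as follows: 3-(trifluoromethyl)phenyl in place of (3-(trifluoromethyl)phenyl)amino on a carbonyl carbon. Going by the values given here, none of the measured steps touches the carbonyl carbon or the amide-type nitrogen; they concern only the substituents on the outer aromatic ring, and none moved the read-out beyond the scatter. Among the compounds with values here, no measured step therefore bears directly on this change. With every measured number already close to the ceiling of the read-out, a step of a number 1 percentage points lower from compound 3 to compound 4 (within the scatter) is expected for compound 4, that is none beyond the scatter. The value of compound 4 in this assay is estimated at 98%, within 88% to 106%.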

Compound 4, a percentage reported as activity, at one concentration (the size of the read-out at that concentration, not a potency): 101%
The estimate for compound 4 lay 3 percentage points below the measured number; measured number inside the range.
By their numbers in this assay, from the lowest: compounds 1, 2, 3 and 4 (each within the scatter of the next).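

Setting 3-(trifluoromethyl)phenyl in place of (3-(trifluoromethyl)phenyl)amino on the carbonyl carbon gives, in this assay, a number 2 percentage points higher from compound 3 to compound 4 (within the scatter) and so takes out the amide-type nitrogen with its 1 hydrogen-bond donor without any step beyond the scatter. Read against the other two ureas, the change gives a number 2 percentage points higher from compound 2 to compound 4 (within the scatter) and a number 4 percentage points higher from compound 1 to compound 4 (within the scatter) so this position, unlike the outer-ring substituents probed earlier, has now been varied, and it too stays inside the scatter. No measurement available here accounts for this result.

Going by these compounds, all four numbers sit near the top of the scale at a single concentration, so whether this position matters where a clear effect is seen remains open. Also open, on these data alone, is whether a morpholine or a carboxylic acid on the carbonyl carbon would move the number beyond the scatter.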